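A few compounds are considered here, and "the series" means these few. Any claim that something is new, unique, unknown or untested is made for them only; others in the source may bear on it.

Of the compounds shown here, three sharing one core have been measured in a functional assay on PANC-1 cells (Homo sapiens) for inhibition, read by sulforhodamine B assay, with a stated time of 48 h; on this read-out higher numbers stand for weaker inhibition of growth and lower numbers for stronger inhibition of growth. Compound 1 (`Oc1ccc(-c2nc3ncccn3c2CN2CCCCC2)cc1`) gives 200 nM, compound 2 (`c1ccc(-c2nc3ncccn3c2CN2CCCC2)cc1`) gives 60 nM, and compound 3 (`c1ccc(-c2nc3ncccn3c2CN2CCCCC2)cc1`) gives 1310 nM. Compound 3 therefore has the highest number of the three and is the weakest growth inhibitor among them.

Compound 4 (`CC(C)(C)c1nc2ncccn2c1CN1CCCCC1`) has not yet been measured. It differs from compound 3 by tert-butyl in place of phenyl on an aromatic carbon. Among the compounds with values here, no measured step makes this replacement, so the evidence is indirect. The closest is a 6.6-fold higher number from compound 1 to compound 3 (0.82 log units; beyond the scatter), a modest step made on the phenyl group that compound 4 loses, with hydrogen in place of hydroxy. The other is a 22-fold higher number from compound 2 to compound 3 (1.34 log units; beyond the scatter), a large step at the piperidin-1-yl group that compound 4 keeps. It shows that a single change in this small set can move the number considerably, but it says nothing about the phenyl group.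

A modest move towards weaker inhibition is therefore expected, though its direction is only loosely supported. The expected change is a 2.1-fold higher number from compound 3 to compound 4 (0.33 log units; beyond the scatter). For compound 4 the estimated value in this assay is 2800 nM, with an expected range from 700 nM to 10000 nM.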

Compound 4, concentration for 50% growth inhibition: 4510 nM
Compound 4: the middle estimate sits 1.6-fold (0.21 log units) below what was measured; low and high end bracket the measured number.
By their numbers in this assay, from the lowest: compound 2; then compound 1; then compound 3; then compound 4.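

The change at this aromatic carbon is now seen directly in this assay: tert-butyl in place of phenyl gives a 3.4-fold higher number from compound 3 to compound 4 (0.54 log units; beyond the scatter), so a group with no ring gives weaker growth inhibition than phenyl, by a modest margin beyond the scatter. Measured against the 4-hydroxyphenyl group, the same tert-butyl group gives a 23-fold higher number from compound 1 to compound 4 (1.35 log units; beyond the scatter), a large step that shows how far the number can move through the group on this carbon alone, with the (piperidin-1-yl)methyl group unchanged. Nothing available here offers a measured reason for either step.

The compounds shown leave open how a smaller chain such as methyl, or an aromatic ring containing nitrogen such as pyridyl, would behave on this carbon, and so whether the aromatic ring itself or simply the size of the group sets the number. They also leave open whether pyrrolidin-1-yl in place of piperidin-1-yl would lower the number with tert-butyl on this carbon as it does with phenyl, and whether an amine or a methoxy group could stand in for the hydroxy group on the phenyl ring.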